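Ester aryl substituent changes in an antiproliferative series

A few compounds are considered here, and "the series" means these few. Any claim that something is new, unique, unknown or untested is made for them only; others in the source may bear on it.

Measured compounds in a functional assay on MCF7 cells (Homo sapiens) for antiproliferative activity, read by sulforhodamine B assay, with a stated time of 48 h, tested at 50 uM; on this read-out lower numbers stand for less inhibition and higher numbers for more inhibition at the one concentration tested (going by the name of the read-out):
compound 1 `COc1ccc(C(=O)Oc2cc3c(cc2C)[C@@H](C(C)C)CC=C3C)cc1` gives 80.1%
compound 2 `COc1cccc(C(=O)Oc2cc3c(cc2C)[C@@H](C(C)C)CC=C3C)c1` gives 11.9%
compound 3 `CC1=CC[C@H](C(C)C)c2cc(C)c(OC(=O)c3cccc(C)c3)cc21` gives 54.9%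

Compound 3 stands second of the three: below compound 1 by a number 25.2 percentage points lower from compound 1 to compound 3 (beyond the scatter), and above compound 2 by a number 43 percentage points higher from compound 2 to compound 3 (beyond the scatter). Compound 4 `CC1=CC[C@H](C(C)C)c2cc(C)c(OC(=O)c3cccc(C(F)(F)F)c3)cc21` differs from compound 3 by trifluoromethyl in place of methyl on an aromatic carbon. Among the measured compounds shown here, no measured step exchanges methyl for trifluoromethyl, so only the neighbouring steps inform the expectation. The step of a number 43 percentage points higher from compound 2 to compound 3 (beyond the scatter) shows that the group at this position moves the read-out strongly, and a number 68.2 percentage points lower from compound 1 to compound 2 (beyond the scatter) shows that the pattern of the aryl ring matters greatly. With two of three aryl variants well below compound 1, a moderate drop from compound 3 is expected, a number 14.9 percentage points lower from compound 3 to compound 4 (beyond the scatter), with wide uncertainty. Compound 4 is therefore estimated at 40%, ranging from 10% to 70%.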

Compound 4, a percentage reported as inhibition, at one concentration (the size of the read-out at that concentration, not a potency): 86%
Compound 4: middle estimate off by 46 percentage points, on the low side; the measured number lies above the stated range.
By their numbers in this assay, from the lowest: compound 2; then compound 3; then compounds 1 and 4 (each within the scatter of the next).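

The step of a number 31.1 percentage points higher from compound 3 to compound 4 (beyond the scatter) and the step of a number 74.1 percentage points higher from compound 2 to compound 4 (beyond the scatter) show that, meta to a large group, exchanging the group alone can raise the read-out well beyond the scatter. At this place the three groups now rank, from low to high, methoxy, methyl and trifluoromethyl. No measurement in hand bears on the reason for this rise.

Going by these compounds, whether an amine, a nitrile or a chlorine atom at this place would follow that rank remains open. So does whether trifluoromethyl would give a similar read-out on the ring pattern of compound 1.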